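Working notes on compound 4 as a variant of compound 1

The compounds below may be only part of what the source reports. "The series", "measured", "known", "first", "only" and "open" are said of these compounds alone.

Compound 1 `Cc1ccc(S(=O)(=O)NC(=O)Nc2ccccc2C(=O)/C=C/c2ccc(N(C)C)cc2)cc1` gives 38.1 ug/mL in an ADME assay on the whole organism for cytotoxicity, with Artemia salina as the target, with a stated time of 24 h (on this read-out higher numbers stand for an effect only at larger amounts of compound and lower numbers for an effect already at smaller amounts), and holds the highest of the three numbers measured; compound 2 `Cc1ccc(S(=O)(=O)NC(=O)Nc2ccccc2C(=O)/C=C/c2ccccc2O)cc1` gives 32.3 ug/mL there, and compound 3 `COc1cc(/C=C/C(=O)c2ccccc2NC(=O)NS(=O)(=O)c2ccc(C)cc2)ccc1O` gives 17.8 ug/mL there. Compound 4 `Cc1ccc(S(=O)(=O)NC(=O)Nc2ccccc2C(=O)/C=C/c2cccc(Br)c2)cc1` differs from compound 1 by 3-bromophenyl in place of 4-(dimethylamino)phenyl on a double-bonded chain carbon bound to a double-bonded chain carbon at that same place. Going by the values given here, two measured steps bear on this change, each replacing the same 4-(dimethylamino)phenyl group: a 1.2-fold lower number from compound 1 to compound 2 (0.07 log units; within the scatter) and a 2.1-fold lower number from compound 1 to compound 3 (0.33 log units; beyond the scatter) both run toward lower numbers, one within the scatter and one modestly beyond it. For 3-bromophenyl a small downward step is therefore expected, a 1.5-fold lower number from compound 1 to compound 4 (0.17 log units; within the scatter) being the working guess, while no step beyond the scatter would also fit. Compound 4 is estimated at 26 ug/mL with a range from 13 ug/mL to 52 ug/mL in this assay.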

Compound 4, concentration for half-maximal effect: 4.02 ug/mL
Compound 4: middle estimate off by 6.5-fold (0.81 log units), on the high side; measured number below the stated range.
By their numbers in this assay, from the lowest: compound 4; then compounds 3, 2 and 1 (each within the scatter of the next, the first and the last beyond it).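

At this place, on a double-bonded chain carbon bound to a double-bonded chain carbon, 3-bromophenyl shifts the number in this assay well beyond the scatter against all three earlier groups (a 9.5-fold lower number from compound 1 to compound 4 (0.98 log units; beyond the scatter); an 8.0-fold lower number from compound 2 to compound 4 (0.90 log units; beyond the scatter); a 4.4-fold lower number from compound 3 to compound 4 (0.65 log units; beyond the scatter)). The position therefore allows much lower numbers than compounds 1, 2 and 3 showed, and compound 4, the only one here with no oxygen or nitrogen on this ring, gives the lowest. No measurement at hand accounts for this shift.

On these data alone, whether the bromine itself matters, or only the loss of those oxygen and nitrogen groups, stays open. Plain phenyl and 3-chlorophenyl would help separate the two.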